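The source may report more compounds than this note shows. Statements on the series, on what has been measured and on what is new or still open speak of the compounds shown alone.

In a functional assay on HeLa cells (Homo sapiens) for inhibition, with a stated time of 72 h (on this read-out lower numbers stand for an effect already at smaller amounts and higher numbers for an effect only at larger amounts of compound), compound 3 (`CCOc1cc(CNCc2ccncc2)ccc1OCc1ccc(Cl)cc1`) gives 2500 nM. This lies within the usual scatter of both compound 1 (`Clc1ccc(COc2ccc(CNCc3ccncc3)cc2)cc1`) at 4000 nM and compound 2 (`COc1cc(CNCc2ccncc2)ccc1OCc1ccc(C)cc1`) at 5000 nM. Compound 4 (`COc1cc(CNCc2ccncc2)ccc1OCc1ccc(Cl)cc1`) differs from compound 3 in one place: hydrogen in place of methyl on a saturated chain carbon bound to an oxygen on an aromatic ring. This puts hydrogen in place of methyl on a saturated chain carbon bound to an oxygen on an aromatic ring, turning ethoxy into methoxy. Among the measured compounds shown here, one measured step bears on this change, ethoxy in place of hydrogen on an aromatic carbon: a 1.6-fold lower number from compound 1 to compound 3 (0.20 log units; within the scatter), which stays within the scatter. No step beyond the scatter is therefore expected in this assay, and the estimated change is a 1.2-fold higher number from compound 3 to compound 4 (0.08 log units; within the scatter). The estimate for compound 4 is 3000 nM, with an expected range from 1300 nM to 6500 nM.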

Compound 4, half-maximal effective concentration: 890 nM
Compound 4: middle estimate off by 3.4-fold (0.53 log units), on the high side, and the stated range ends above it.
By their numbers in this assay, from the lowest: compound 4; then compounds 3, 1 and 2 (each within the scatter of the next).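

The step from ethoxy to methoxy gives a 2.8-fold lower number from compound 3 to compound 4 (0.45 log units; beyond the scatter) in this assay, so this small trim at the chain end matters. Ethoxy had stayed within the scatter of hydrogen, whereas methoxy in place of hydrogen gives a 4.5-fold lower number from compound 1 to compound 4 (0.65 log units; beyond the scatter). With methoxy held fixed, chloro in place of methyl gives a 5.6-fold lower number from compound 2 to compound 4 (0.75 log units; beyond the scatter), so the change at this second place also counts.

No measurement available here explains these steps. As far as these compounds go, how a hydroxyl group or a longer chain such as propoxy would compare with methoxy at this place remains open.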